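Alkynyl substituent variation in a weakly antiproliferative uracil series

This account rests on a few compounds, and the source may have more. Where it says the series, first, only, none or still open, it means among the compounds named here.

Measured so far:
Compound 1 `Cc1ccc(C#Cc2cn(C/C=C\CN3C(=O)c4ccccc4C3=O)c(=O)[nH]c2=O)cc1` — 266000 nM
Compound 2 `O=C1c2ccccc2C(=O)N1C/C=C\Cn1cc(C#CCCc2ccccc2)c(=O)[nH]c1=O` — 146000 nM

In a functional assay on MOLT-4 cells (Homo sapiens) for antiproliferative activity, read by MTT assay, with a stated time of 3 days (a higher number here means a weaker inhibitor, a lower number a stronger inhibitor), compound 2 shows the lowest of the two numbers; its nearest neighbour, compound 1, sits a step away that the data describe as within the scatter, so the two cannot be ordered. Among the measured compounds shown here, the one measured step, a 1.8-fold lower number from compound 1 to compound 2 (0.26 log units; within the scatter), replaces 4-methylphenyl with phenethyl on a triple-bonded carbon and is itself within the scatter.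

Compound 3 `CCCCc1ccc(C#Cc2cn(C/C=C\CN3C(=O)c4ccccc4C3=O)c(=O)[nH]c2=O)cc1` has not yet been measured. It differs from compound 2 in one place: 4-butylphenyl in place of phenethyl on a triple-bonded carbon. For the measured compounds named here, the only step that bears on this change is the one from compound 1 to compound 2, which exchanged one aromatic group for another at the same triple-bonded carbon and moved the number by less than the scatter. On that basis no step beyond the scatter is expected in this assay for the move to a 4-butylphenyl group; the change from compound 2 to compound 3 is estimated at a 1.2-fold higher number from compound 2 to compound 3 (0.09 log units; within the scatter). Compound 3 is therefore expected to give about 180000 nM in this assay, within a range of 70000 nM to 450000 nM.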

Compound 3, half-maximal inhibitory concentration: 31000 nM
The estimate for compound 3 lay 5.8-fold (0.76 log units) above the measured number; the measured number lies below the stated range.
By their numbers in this assay, from the lowest: compound 3; then compounds 2 and 1 (each within the scatter of the next).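

In this assay, the group on the triple-bonded carbon can shift the number beyond the scatter, which the earlier pair of compounds did not show: 4-butylphenyl in place of phenethyl gives a 4.7-fold lower number from compound 2 to compound 3 (0.67 log units; beyond the scatter). The comparison with the 4-methylphenyl compound shows that a change confined to the substituent on the aromatic ring is enough, since propyl in place of hydrogen on a saturated chain carbon bound to an aromatic carbon gives an 8.6-fold lower number from compound 1 to compound 3 (0.93 log units; beyond the scatter). Nothing available here accounts for the size of either step.

The three compounds shown cannot tell whether the number keeps falling as the chain on the aromatic ring grows, since a single longer chain, the butyl group, stands against the methyl group of compound 1, and intermediate ethyl and propyl groups or a longer hexyl chain would be needed to trace any trend. They also leave open whether the step depends on that chain being purely carbon, which an amine or a carboxylic acid at the same place would test.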